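The source may report more compounds than this note shows. Statements on the series, on what has been measured and on what is new or still open speak of the compounds shown alone.

Measured in a functional assay on A549 cells (Homo sapiens) for antiproliferative activity, read by MTT assay, with a stated time of 48 h; on this read-out higher numbers stand for weaker inhibition and lower numbers for stronger inhibition:
- compound 1 `COc1ccc(C(=O)c2ccc(OC)c3c2C=CC(C)(C)O3)c(NC(=O)CO)c1`: 100 nM
- compound 2 `COc1ccc(C(=O)c2ccc3c(c2)C=CC(C)(C)O3)c(NC(=O)CO)c1`: 90 nM
- compound 3 `COc1ccc(C(=O)c2ccc(OC)c3c2OC(C)(C)C=C3)c(NC(=O)CN)c1`: 270 nM

In this assay, compound 1 at 100 nM lies within the scatter of compound 2 at 90 nM. Compound 3 has a higher number than either, and its gap to compound 1 lies beyond the scatter. The next compound to be tested, compound 4 `CNCC(=O)Nc1cc(OC)ccc1C(=O)c1ccc(OC)c2c1C=CC(C)(C)O2`, keeps the core of compound 1 and changes only the end of the side chain: methylamino in place of hydroxy on a saturated chain carbon bound to a carbonyl carbon. Methylamino thus stands in place of hydroxy on a saturated chain carbon bound to a carbonyl carbon.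

Among the measured compounds shown here, no measured pair isolates this change, so the expectation rests on indirect evidence. For the measured compounds named here, compound 3, the only measured compound with a nitrogen group at that end of the chain, gives 270 nM, but its core also differs from that of compound 1. That value suggests weaker inhibition rather than stronger, though only tentatively. The expected change is a 2.8-fold higher number from compound 1 to compound 4 (0.45 log units; beyond the scatter), a modest rise in the number. For compound 4, the estimated value in this assay is 280 nM, with an expected range of 100 nM to 800 nM.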

Compound 4, half-maximal inhibitory concentration: 1370 nM
Estimate against measurement, compound 4: 4.9-fold (0.69 log units) below; the measured number lies above the stated range.
By their numbers in this assay, from the lowest: compounds 2 and 1 (each within the scatter of the next); then compound 3; then compound 4.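

In this assay, among the compounds shown here, putting methylamino in place of hydroxy on a saturated chain carbon bound to a carbonyl carbon gives a 14-fold higher number from compound 1 to compound 4 (1.14 log units; beyond the scatter), a large step beyond the scatter and the first reading of this change on an unchanged core. For the compounds shown here, until now the nitrogen end of the chain could be seen only in compound 3, whose core also differs, so this pair is the first to show that the number at this position responds strongly to the end group, even though hydroxy and methylamino count alike in hydrogen-bond donors and acceptors and neither carries a net charge. Nothing measured here accounts for the size of this step.

The compounds shown leave open whether the rise belongs to the nitrogen itself or to its methyl group, a question that a plain amine or a dimethylamino group on the core of compound 1 would address. From the compounds shown here alone, it also remains open how a carboxylic acid or a longer chain at this end would read, and whether methylamino would give a step of similar size on the core of compound 2.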